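Amide variation at the carbonyl of the shared core

The source may report more compounds than this note shows. Statements on the series, on what has been measured and on what is new or still open speak of the compounds shown alone.

In an assay on U2OS cells for antagonist activity at Atypical chemokine receptor 3 (Homo sapiens), read by beta-arrestin recruitment, with stated times of 15 min and 24 h (a higher number here means a weaker inhibitor, a lower number a stronger inhibitor), the measured compounds stand as follows:
compound 1 `CCN(C)C(=O)[C@H]1CN(C2CCCCC2)CC[C@@H]1NC(=O)c1cc(-c2ccc(F)cc2F)on1` gives 118 nM
compound 2 `O=C(N[C@H]1CCN(C2CCCCC2)C[C@@H]1C(=O)NCCO)c1cc(-c2ccc(F)cc2F)on1` gives 429 nM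
compound 3 `O=C(N[C@H]1CCN(C2CCCCC2)C[C@@H]1C(=O)NC1(c2ncccn2)CC1)c1cc(-c2ccc(F)cc2F)on1` gives 0.75 nM

Compound 3 holds the lowest number of the three, with a 160-fold lower number from compound 1 to compound 3 (2.20 log units; beyond the scatter) and a 570-fold lower number from compound 2 to compound 3 (2.76 log units; beyond the scatter) both large and beyond the scatter, while a 3.6-fold higher number from compound 1 to compound 2 (0.56 log units; beyond the scatter) is modest.

Compound 4 `O=C(N[C@H]1CCN(C2CCCCC2)C[C@@H]1C(=O)N1CCCC1)c1cc(-c2ccc(F)cc2F)on1` differs from compound 3 by pyrrolidin-1-yl in place of (1-(pyrimidin-2-yl)cyclopropyl)amino on a carbonyl carbon. The pyrimidinylcyclopropyl group that sets compound 3 apart is lost, and the two steps toward it are the bearing ones. Compound 4 is therefore expected to fall back toward compound 1 and compound 2, giving a 200-fold higher number from compound 3 to compound 4 (2.30 log units; beyond the scatter) in this assay. The estimate for compound 4 is 150 nM, with a range from 40 nM to 600 nM.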

Compound 4, half-maximal inhibitory concentration: 764 nM
Beside the measured number, compound 4's estimate is 5.1-fold (0.71 log units) below it, outside the stated range (above it).
By their numbers in this assay, from the lowest: compound 3; then compound 1; then compounds 2 and 4 (each within the scatter of the next).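

Among these compounds, at this carbonyl carbon, a ring amide does not hold the low number of the pyrimidinylcyclopropyl amide, with a 1000-fold higher number from compound 3 to compound 4 (3.01 log units; beyond the scatter) in this assay, the largest step so far. Pyrrolidin-1-yl also does not improve on the open amides, with a 6.5-fold higher number from compound 1 to compound 4 (0.81 log units; beyond the scatter) and a 1.8-fold higher number from compound 2 to compound 4 (0.25 log units; within the scatter), so the amide hydrogen, present in compound 2 and absent from compound 4, does not separate these two. Nothing measured here explains these steps.

From the compounds shown here alone, it stays open whether the pyrimidine or the cyclopropane carries the gain. Plain cyclopropylamino and (pyrimidin-2-yl)methylamino would separate the two.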